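This account rests on a few compounds, and the source may have more. Where it says the series, first, only, none or still open, it means among the compounds named here.

In a functional assay on the whole organism for antagonist activity, with Mus musculus as the target (a lower number here means that less compound is needed, a higher number that more compound is needed for the effect), three compounds sharing one core have been measured so far. Compound 1 `Cc1ccc(-c2nnc(S(C)(=O)=O)n2C)cc1` gives > 200 mg/kg, which is a limit and not a number. Compound 2 `CSc1nnc(-c2ccccc2Cl)n1C` gives > 50 mg/kg, which is also a limit. Among the measured compounds shown here, compound 3 `CSc1nnc(-c2ccccc2F)n1C` gives 8.8 mg/kg, the only actual number among the three, and so it is the sole firm reference point.

The next compound is compound 4 `CC[S+]([O-])c1nnc(-c2ccccc2F)n1C`, which keeps the rest of compound 3 but loses methylsulfanyl on an aromatic carbon of the five-membered aromatic ring: a group of 4 heavy atoms (2 carbon, 1 oxygen, 1 sulfur; no ring) in place of a group of 2 heavy atoms (1 carbon, 1 sulfur; no ring), on an aromatic carbon.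

For the measured compounds named here, only one measured step is available, an at least 5.6-fold lower number from compound 2 to compound 3 (0.75 log units; beyond the scatter). It is fluoro in place of chloro at a different place, so it shows that a single replacement can move the result beyond the scatter, but it does not measure this change. The only hint on direction comes from compound 1, which also lacks methylsulfanyl, differs elsewhere as well, and reports the limit > 200 mg/kg. That hint is weak, so only a small rise in the number is expected.

The expected change is a 2.3-fold higher number from compound 3 to compound 4 (0.36 log units; beyond the scatter). For compound 4 the estimated value is 20 mg/kg, with an expected range from 4 mg/kg to 80 mg/kg.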

Compound 4, dose for half-maximal effect: 32.7 mg/kg
Beside the measured number, compound 4's estimate is 1.6-fold (0.21 log units) below it; measured number inside the range.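

The aromatic carbon between two ring nitrogen atoms now has a measured step of its own: in this assay there is a 3.7-fold higher number from compound 3 to compound 4 (0.57 log units; beyond the scatter), so more compound is needed once the group of 4 heavy atoms replaces methylsulfanyl, yet the read-out remains a number and not a limit. Among the compounds shown here, until now, the only measured step lay at a different place, so this result is the first to show that a change at this position can also move the result beyond the scatter, while its modest size shows that methylsulfanyl can be replaced here without the effect being lost. Nothing shown gives a measured property that would account for the size of this step.

The entering group brings its added carbon and its oxygen together, and the compounds shown do not separate what each contributes to the step. They also leave open how an amine or a longer chain on this aromatic carbon would read in this assay, and whether the step would be the same with chloro in place of fluoro elsewhere in the molecule.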